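Chlorophenyl amides compared in a growth inhibition test

A few compounds are considered here, and "the series" means these few. Any claim that something is new, unique, unknown or untested is made for them only; others in the source may bear on it.

Measured so far:
compound 1 `O=C(CCCCC(CCSC(=O)c1ccccc1)SC(=O)c1ccccc1)Nc1ccccc1Cl`: 15.1%
compound 2 `O=C(CCCCC(CCSC(=O)c1ccccc1)SC(=O)c1ccccc1)Nc1cccc(Cl)c1`: 15.6%

In a functional assay on NCI-H460 cells (Homo sapiens) for inhibition, read by MTT assay, with a stated time of 24 h, tested at 0.1 ug/mL (a lower number here means less inhibition of growth, a higher number more inhibition of growth at the concentration tested), compound 2 gives 15.6%, which stands level with compound 1 at 15.1%, the two lying within the scatter of each other. The next structure is compound 3 `O=C(CCCCC(CCSC(=O)c1ccccc1)SC(=O)c1ccccc1)Nc1ccc(Cl)cc1`. The change is 4-chlorophenyl in place of 3-chlorophenyl on an amide-type nitrogen, with the rest of the molecule the same. Among the measured compounds shown here, only one measured step bears on this: a number 0.5 percentage points higher from compound 1 to compound 2 (within the scatter), with 3-chlorophenyl in place of 2-chlorophenyl at that same place. On that evidence, no step beyond the scatter is expected in this assay, and the data point to no direction. The expected change is a number 0.4 percentage points higher from compound 2 to compound 3 (within the scatter). Compound 3 is estimated at 16%, within an expected range of 6% to 29%.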

Compound 3, percent growth inhibition at one concentration: 9.36%
Compound 3: the middle estimate sits 6.6 percentage points above what was measured; the range from low to high includes it.
By their numbers in this assay, from the lowest: compounds 3, 1 and 2 (each within the scatter of the next).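

In this assay the three chlorophenyl amides can now be set side by side: 4-chlorophenyl in place of 3-chlorophenyl on the amide-type nitrogen gives a number 6.2 percentage points lower from compound 2 to compound 3 (within the scatter), and 4-chlorophenyl in place of 2-chlorophenyl gives a number 5.7 percentage points lower from compound 1 to compound 3 (within the scatter). Moving the chlorine around this phenyl has therefore produced no step beyond the scatter in any of the listed pairs. Nothing available offers a reason for these numbers.

Still open, going by these compounds, is whether a group other than chlorine on this phenyl, such as a methoxy group, a nitrile or a carboxylic acid, or a phenyl with no chlorine at all, would shift the number beyond the scatter. Also open, on these data alone, is whether a longer chain before the amide would do so.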